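This account rests on a few compounds, and the source may have more. Where it says the series, first, only, none or still open, it means among the compounds named here.

Measured in a functional assay on PC-3 cells (Homo sapiens) for antiproliferative activity, read by MTT assay, with a stated time of 48 h; a higher number here means a weaker inhibitor, a lower number a stronger inhibitor:
compound 1 `COc1cc(/C=C/C(C)=O)ccc1OCc1cn(-c2c(F)cccc2F)nn1` gives 24200 nM
compound 2 `COc1cc(/C=C/C(C)=O)ccc1OCc1cn(-c2ccc(NC(=O)c3ccccc3)cc2)nn1` gives 76800 nM
compound 3 `COc1cc(/C=C/C(C)=O)ccc1OCc1cn(-c2ccc(C(F)(F)F)c(C(F)(F)F)c2)nn1` gives 67200 nM

Compound 2 has the highest of the three numbers; its value and that of compound 3 lie within the scatter of each other, while compound 1 sits beyond the scatter with a lower number.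

Compound 4 `CCOC(=O)c1ccc(-n2cc(COc3ccc(/C=C/C(C)=O)cc3OC)nn2)cc1` differs from compound 2 by ethoxycarbonyl in place of benzamido on an aromatic carbon, para to a large group. Among the compounds with values here, no measured pair here shows such a change, so the step is uncertain. Given that compound 3 with a different substitution on the same ring gives 67200 nM, the step from compound 2 to compound 4 is expected to be small, toward a lower number, and probably within the scatter: a 1.5-fold lower number from compound 2 to compound 4 (0.19 log units; within the scatter). Compound 4 is therefore estimated at 50000 nM, within 15000 nM to 150000 nM.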

Compound 4, half-maximal inhibitory concentration: 59200 nM
The estimate for compound 4 lay 1.2-fold (0.07 log units) below the measured number, and the stated range covers the measured number.
By their numbers in this assay, from the lowest: compound 1; then compounds 4, 3 and 2 (each within the scatter of the next).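

In this assay, within the data shown here, ethoxycarbonyl in place of benzamido on an aromatic carbon, para to a large group, gives a 1.3-fold lower number from compound 2 to compound 4 (0.11 log units; within the scatter) and is the first single-place step. At this position, the exchange removes a six-membered aromatic ring and a hydrogen-bond donor, yet the step stays within the scatter. Nothing on hand explains why the two groups read alike.

Open, going by these compounds, is how a carboxylic acid or a primary amine at this position would read. Also open, on these data alone, is whether a longer ester chain here would stay within the scatter of compound 4.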